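Methyl in place of chloro on compound 3

This account rests on a few compounds, and the source may have more. Where it says the series, first, only, none or still open, it means among the compounds named here.

Four compounds are under review, and all readings come from a functional assay on KYSE-450 cells (Homo sapiens) for inhibition, read by CCK-8 assay, with a stated time of 48 h; a higher number here means a weaker inhibitor, a lower number a stronger inhibitor. Compound 1 `COc1ccc(CN(C(=O)CSC(=S)N2CCc3cc(Br)ccc32)c2cc(OC)c(OC)c(OC)c2)cc1` gives > 20000 nM, which is a limit and not a number. For the measured compounds named here, compound 2 `COc1ccc(CN(C(=O)CN2CCN(C(=O)OC(C)(C)C)CC2)c2cc(OC)c(OC)c(OC)c2)cc1` gives 8170 nM, the only numeric reading so far. Compound 3 `COc1ccc(CN(C(=O)CSC(=S)N2CCN(C(=O)OC(C)(C)C)CC2)c2ccc(Cl)cc2)cc1` gives > 20000 nM, which is also a limit and not a number. Compound 3 therefore has no numeric reading, and its place in the series is the limit of > 20000 nM in this assay, at which 2 of the 3 values shown sit.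

The next compound is compound 4 `COc1ccc(CN(C(=O)CSC(=S)N2CCN(C(=O)OC(C)(C)C)CC2)c2ccc(C)cc2)cc1`. It differs from compound 3 by methyl in place of chloro on an aromatic carbon, para to a large group: methyl in place of chloro on an aromatic carbon. Going by the values given here, the series offers no measured step between two compounds that differ in one place, so this change has no direct precedent here.

In this assay the estimated a number no higher from compound 3 to compound 4 (the limit leaves the size open) is expected to lie within the scatter, with no direction favoured. This expectation rests on compound 3 alone, which reads > 20000 nM, a limit. A further limit rather than a number is therefore a likely outcome. The expected value for compound 4 is 20000 nM, with an estimated range from 8000 nM to 30000 nM.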

Compound 4, half-maximal inhibitory concentration: > 20000 nM
Compound 4 gave a limit, no number; the forecaster's own chance of this, stated with the estimate: 65%; the middle value lies on the limit itself.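

Compound 4 reads > 20000 nM in this assay, a limit and not a number. Compound 3 reads > 20000 nM, also a limit, so no step can be read between these two compounds. How 4-chlorophenyl and 4-methylphenyl compare stays open, with most of the series resting on one reading: the limit of > 20000 nM in this assay, at which 3 of the 4 values shown sit.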